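A Shorter Chain on a Core Already at the Limit

The source may report more compounds than this note shows. Statements on the series, on what has been measured and on what is new or still open speak of the compounds shown alone.

This short series rests on one read-out, a functional assay for inhibition, with Homo sapiens as the target; on this read-out lower numbers stand for stronger inhibition and higher numbers for weaker inhibition. Compound 1, with the structure `CCCCc1nnc(O)n2c(CCC)nc(C)c12`, is reported in this assay only as a limit of > 48000 nM. Compound 2, with the structure `CSc1nncc2c(C)nc(C(C)C)n12`, likewise gives only a limit of > 48000 nM. Compound 3, with the structure `C=CCn1ncc2c(CCC)ncn2c1=O`, also stands at a limit in this assay, > 48000 nM, so no number for it is known. Nothing separates these three entries from one another, because the limit of > 48000 nM in this assay, at which 3 of the 3 values shown sit, is where every value shown rests.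

Going by the values given here, no step between two measured compounds is available, so the move to compound 4, with the structure `C=CCn1ncc2c(C)ncn2c1=O`, cannot be scaled against a measured precedent. The change is hydrogen in place of ethyl on a saturated chain carbon bound to an aromatic carbon, which, cut one bond further out, reads as propyl to methyl. With every shown value sitting at the same limit, the expected step from compound 3 to compound 4 is a step that the limit leaves unreadable from compound 3 to compound 4, most likely none that rises out of the scatter, and the measurement may again return only a limit. Compound 4 is therefore estimated at 60000 nM, within a range from 15000 nM to 250000 nM.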

Compound 4, half-maximal inhibitory concentration: > 48000 nM
Compound 4 was reported as a limit (the forecaster's own chance of this, stated with the estimate: 85%); the middle value lies beyond the limit too.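

Going by these compounds alone, no step from compound 3 to compound 4 can be read, as both are reported only as limits, so the swap of propyl for methyl has no measurable size: the limit of > 48000 nM in this assay, at which 4 of the 4 values shown sit.

The compounds shown leave open whether any change to the shared core would give an actual number in this assay, and which changes would matter for inhibition.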